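Changing the chain end of compound 2

The compounds below may be only part of what the source reports. "The series", "measured", "known", "first", "only" and "open" are said of these compounds alone.

In a functional assay on A549 cells (Homo sapiens) for antiproliferative activity, read by MTT assay, with a stated time of 72 h (a higher number here means a weaker inhibitor, a lower number a stronger inhibitor), compound 1 (`COc1cc2ncnc(N3CCc4ccccc43)c2cc1NC(=O)/C=C/C(C)C`) gives 6410 nM and compound 2 (`CC(C)/C=C/C(=O)Nc1cc2c(N3CCc4ccccc43)ncnc2cc1O[C@@H]1CCOC1`) gives 8520 nM while compound 3 (`CC(C)/C=C/C(=O)Nc1cc2c(N3CCCc4ccccc43)ncnc2cc1O[C@@H]1CCOC1`) gives 6820 nM as its reading. These three numbers cannot be told apart, so compound 2 stands level with the other two: both measured steps, one of a 1.3-fold higher number from compound 1 to compound 2 (0.12 log units; within the scatter) and one of a 1.2-fold lower number from compound 2 to compound 3 (0.10 log units; within the scatter), lie within the scatter.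

Compound 4 (`O=C(/C=C/CN1CCCC1)Nc1cc2c(N3CCc4ccccc43)ncnc2cc1O[C@@H]1CCOC1`) has not been measured yet. It differs from compound 2 only at the end of the chain, where (pyrrolidin-1-yl)methyl replaces isopropyl on a double-bonded chain carbon bound to a double-bonded chain carbon ((pyrrolidin-1-yl)methyl in place of isopropyl on a double-bonded chain carbon bound to a double-bonded chain carbon).

The two measured steps bear on this only indirectly. One put oxolan-3-yl in place of methyl on an oxygen, and the other put 1,2,3,4-tetrahydroquinolin-1-yl in place of 2,3-dihydro-1H-indol-1-yl, so neither touched this chain. Among the measured compounds shown here, no measured compound carries the new group, which leaves the range wide. Only a small shift is expected in this assay, leaning slightly toward a lower number as a judgement and not as a measured trend. The estimated change is a 1.7-fold lower number from compound 2 to compound 4 (0.23 log units; within the scatter) and it is not expected to stand clearly beyond the scatter. Compound 4 is expected at 5000 nM (estimated range 1500 nM to 12000 nM).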

Compound 4, half-maximal inhibitory concentration: 2230 nM
The estimate for compound 4 lay 2.2-fold (0.35 log units) above the measured number, within the range that was stated.
By their numbers in this assay, from the lowest: compound 4; then compounds 1, 3 and 2 (each within the scatter of the next).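

Among the compounds shown here, the chain end is the first place in this set where a single change moves the reading beyond the scatter: in this assay, (pyrrolidin-1-yl)methyl in place of isopropyl gives a 3.8-fold lower number from compound 2 to compound 4 (0.58 log units; beyond the scatter), a modest step. The earlier swaps, oxolan-3-yl for methyl and 1,2,3,4-tetrahydroquinolin-1-yl for 2,3-dihydro-1H-indol-1-yl, both stayed within the scatter, so this position on a double-bonded chain carbon bound to a double-bonded chain carbon is the only one shown so far where the number responds. The incoming group brings 1 nitrogen, 1 hydrogen-bond acceptor and a five-membered non-aromatic ring, none of which isopropyl has, and nothing measured here explains why the number fell.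

This single step cannot separate the ring from the nitrogen: a cyclopentylmethyl group, with the ring but only carbon, or a (dimethylamino)methyl group, with the nitrogen but no ring, would pull the two apart. On these data alone, it also remains open whether the same chain end would lower the number on the core of compound 3, or alongside the methyl on oxygen of compound 1.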